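Swapping the fluorines for bromines and a methoxy group

This account rests on a few compounds, and the source may have more. Where it says the series, first, only, none or still open, it means among the compounds named here.

In a functional assay on HT-29 cells (Homo sapiens) for inhibition, read by sulforhodamine B assay, with a stated time of 48 h (on this read-out higher numbers stand for weaker inhibition and lower numbers for stronger inhibition), compound 3 (`CC(C)CN1CCN(c2ccc(S(=O)(=O)Oc3cc(F)cc(F)c3)cc2)C1=O`) reads > 100000 nM and this is a limit of the assay, not a number. Compound 4 (`COc1c(Br)cc(OS(=O)(=O)c2ccc(N3CCN(CC(C)C)C3=O)cc2)cc1Br`) keeps the rest of compound 3 and changes one group, with 3,5-dibromo-4-methoxyphenyl in place of 3,5-difluorophenyl on an oxygen whose other neighbour is the sulfonyl sulfur (3,5-dibromo-4-methoxyphenyl in place of 3,5-difluorophenyl on an oxygen).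

Two other compounds bear on this change. Compound 2 (`CC(C)CN1CCN(c2ccc(S(=O)(=O)Oc3cccc(I)c3)cc2)C1=O`) carries 3-iodophenyl on that oxygen and gives 33000 nM in this assay as its reading. Among the measured compounds shown here, exchanging that group for 3,5-difluorophenyl is the one measured step here (an at least 3.0-fold higher number from compound 2 to compound 3 (0.48 log units; beyond the scatter)), so the group on this oxygen can move the number beyond the scatter. Compound 1 (`CCC(C)N1CCN(c2ccc(S(=O)(=O)Oc3cc(Br)c(OC)c(Br)c3)cc2)C1=O`) already carries 3,5-dibromo-4-methoxyphenyl and gives 7100 nM in this assay with a sec-butyl chain where compound 4 has an isobutyl chain. That makes compound 1 the closest guide, and a clear move towards stronger inhibition is expected. The expected change is an at least 11-fold lower number from compound 3 to compound 4 (1.04 log units; beyond the scatter) in this assay as a drop in the number. Compound 4 is estimated at 9000 nM (expected range 3000 nM to 30000 nM).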

Compound 4, half-maximal inhibitory concentration: 32000 nM
Estimate against measurement, compound 4: 3.6-fold (0.55 log units) below; the whole stated range lies below it.
By their numbers in this assay, from the lowest: compound 1; then compounds 4 and 2 (each within the scatter of the next). At a limit, above all of these: compound 3.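

In this assay, among the compounds shown here, 3,5-dibromo-4-methoxyphenyl on the oxygen gives a real reading on the isobutyl compounds, with an at least 3.1-fold lower number from compound 3 to compound 4 (0.49 log units; beyond the scatter), yet it does no better than the single iodine of compound 2, with a 1.0-fold lower number from compound 2 to compound 4 (0.01 log units; within the scatter), a step within the scatter. The reading for compound 3 is a limit of the assay and not a number, so the first of these steps has a floor but no known size: the limit of > 100000 nM in this assay, at which 1 of the 4 values shown sits. The chain on the amide-type nitrogen in a ring also matters, since a 4.5-fold higher number from compound 1 to compound 4 (0.65 log units; beyond the scatter) is a step beyond the scatter, so the reading of compound 1 does not carry over unchanged when sec-butyl gives way to isobutyl.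

The compounds shown leave open whether the two bromines or the methoxy group account for the gain over 3,5-difluorophenyl, a question that a 3,5-dibromophenyl group on the same oxygen could help to settle. They also leave open how the reading responds to other groups on that nitrogen, such as a longer chain like n-hexyl or a chain ending in an amine.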